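The source may report more compounds than this note shows. Statements on the series, on what has been measured and on what is new or still open speak of the compounds shown alone.

Compound 1 `CC(C)Nc1nc(NCc2ccco2)c2cccc(Cl)c2n1` gives in a physicochemical assay for solubility, at pH 7.4 (on this read-out lower numbers stand for lower solubility and higher numbers for higher solubility), the value <= 5000 nM, which is a limit of the assay and not a number.
Compound 2 `CC(C)Nc1nc(NCc2ccco2)c2c(Cl)cccc2n1` gives in this assay the value <= 10000 nM, again a limit.
Compound 3 `Cc1cccc2c(NCc3ccco3)nc(NC(C)C)nc12` gives in this assay the value <= 20000 nM, also a limit.

Compound 1 and compound 2 are built from the same atoms joined differently; the difference between the two cores is not broken down here. From compound 1 to compound 3 the change is methyl in place of chloro on an aromatic carbon. In this assay that change made a step that the two limits leave unreadable from compound 1 to compound 3, because compound 1 sits at the limit of <= 5000 nM in this assay, at which 1 of the 3 values shown sits, and compound 3 sits at the limit of <= 20000 nM in this assay, at which 1 of the 3 values shown sits, so nothing can be said about its size.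

Compound 4 `Cc1cccc2nc(NC(C)C)nc(NCc3ccco3)c12` has not been measured. It differs from compound 2 by methyl in place of chloro on an aromatic carbon, the same change as from compound 1 to compound 3, at a place described in the same words. Among the measured compounds shown here, with all three known values being limits, there is no measured step to lean on. Compound 2 sits at the limit of <= 10000 nM in this assay, at which 1 of the 3 values shown sits. For compound 4 the step from compound 2 is expected to be a step that the limit leaves unreadable from compound 2 to compound 4, and it is likely that this assay again returns only a limit. Compound 4 is estimated to give about 8000 nM, most probably between 2000 nM and 30000 nM.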

Compound 4, solubility: <= 10000 nM
Compound 4: no number, only a limit; the forecaster's own chance of this, stated with the estimate: 60%; the middle value lies beyond the limit too.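

In this assay compound 4 gives <= 10000 nM, which is a limit of the assay and not a number. Compound 2 is also known only as a limit, so no step can be read between compound 2 and compound 4. The compounds shown leave open whether methyl in place of chloro on an aromatic carbon changes solubility at all, and by how much.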